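The source may hold more compounds than are shown below. What is called first, only, known or untested is meant among the compounds shown, and "the series" means these compounds.

Measured compounds:
- compound 1 `CC(C)(C)OC(=O)NCCCCCN1C(Nc2ccc(-c3ccccc3)cc2)=Nc2ccccc2C1CC(=O)NCc1ccccc1` gives 1590 nM in a functional assay on SK-MEL-2 cells (Homo sapiens) for inhibition, read by sulforhodamine B assay, with a stated time of 72 h; a higher number here means a weaker inhibitor of growth, a lower number a stronger inhibitor of growth
- compound 3 `CC(C)(C)OC(=O)NCCCCCNC1=Nc2ccccc2C(CC(=O)NCc2ccccc2)N1c1ccccc1` gives 2020 nM in this assay
- compound 2 `CN(C)C1=Nc2ccccc2C(CC(=O)NCc2ccc(N)cc2)N1c1ccccc1` gives 44000 nM in this assay

Compound 2 stands at the top of these three numbers, and so is the weakest growth inhibitor of the set: compound 3 and compound 1 both sit far lower, at distances well beyond the scatter of repeat runs. Compound 4 `CN(C)C1=Nc2ccccc2C(CC(=O)NCc2ccc([N+](=O)[O-])cc2)N1c1ccccc1` is the partner of compound 2 that has not yet been measured. It differs from compound 2 in one place: nitro in place of amino on an aromatic carbon — nitro in place of amino on an aromatic carbon, para to a large group. For the measured compounds named here, no measured pair in this set shows this exact swap, so the size of the step can only be guessed. With no shown step to lean on, a step of no more than the usual scatter in this assay seems the fairest expectation, in either direction. Compound 4 is therefore estimated at 30000 nM, within a range from 8000 nM to 100000 nM, which means an expected step of a 1.5-fold lower number from compound 2 to compound 4 (0.17 log units; within the scatter).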

Compound 4, concentration for 50% growth inhibition: 31600 nM
Beside the measured number, compound 4's estimate is 1.1-fold (0.02 log units) below it; the measured number falls inside the stated range.
By their numbers in this assay, from the lowest: compounds 1 and 3 (each within the scatter of the next); then compounds 4 and 2 (each within the scatter of the next).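

In this assay, for the compounds shown here, the change from 4-aminobenzyl to 4-nitrobenzyl is the first one-place change that can be read in this set, and it gives a 1.4-fold lower number from compound 2 to compound 4 (0.14 log units; within the scatter). On this aromatic carbon, para to a large group, the amino group's hydrogen-bond donor is lost and the group grows from one heavy atom to three, yet no difference beyond the scatter appears, so compound 2 and compound 4 cannot be put in order. No supporting measurement is available to say why this position responds so little.

Going by these compounds, whether a carboxylic acid or a methoxy group at this same place would also leave the number within the scatter remains open. So does whether the swap from amino to nitro would behave the same way on another background, such as that of compound 3.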